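This account rests on a few compounds, and the source may have more. Where it says the series, first, only, none or still open, it means among the compounds named here.

Working notes on the series.

Among the measured compounds shown here, compound 2 `COc1cc2c(Oc3ccc(NC(=O)c4cc(-c5ccc(F)cc5)nc5ccccc45)cc3F)ccnc2cc1OCCCN1CCCCC1` holds the lowest of the two numbers so far: in a functional assay on NCI-H460 cells (Homo sapiens) for cytotoxicity, read by MTT assay, with a stated time of 72 h (on this read-out lower numbers stand for stronger inhibition and higher numbers for weaker inhibition), compound 2 gives 21 nM, and its nearest neighbour, compound 1 `COc1cc2c(Oc3ccc(NC(=O)c4cc(-c5ccccc5)nc5ccccc45)cc3F)ccnc2cc1OCCCN1CCCCC1`, gives 110 nM. For the measured compounds named here, the single measured step, a 5.2-fold lower number from compound 1 to compound 2 (0.72 log units; beyond the scatter), covers fluoro in place of hydrogen on an aromatic carbon.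

Compound 3 `COc1cc2c(Oc3ccc(NC(=O)c4cc(-c5cccc(Cl)c5)nc5ccccc45)cc3F)ccnc2cc1OCCCN1CCCCC1` differs from compound 2 by 3-chlorophenyl in place of 4-fluorophenyl on an aromatic carbon. Going by the values given here, no measured step covers a chlorine or a shift of the halogen to the other position, so the only guide is that the halogen-bearing ring itself matters, as the step from compound 1 to compound 2 showed. With the known favourable fluoro removed and a different halogen at a different place, compound 3 is expected to land between its two neighbours, at an estimated 50 nM within 15 nM to 170 nM, a step of a 2.4-fold higher number from compound 2 to compound 3 (0.38 log units; beyond the scatter) in this assay.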

Compound 3, half-maximal inhibitory concentration: 11 nM
For compound 3 the middle estimate is 4.5-fold (0.66 log units) above the measured one, outside the stated range (below it).
By their numbers in this assay, from the lowest: compounds 3 and 2 (each within the scatter of the next); then compound 1.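

In this assay, the exchange of 4-fluorophenyl for 3-chlorophenyl gives a 1.9-fold lower number from compound 2 to compound 3 (0.28 log units; within the scatter) and so does not separate the two halogen-bearing rings. Measured against the unsubstituted phenyl, the chloro group gives a 10-fold lower number from compound 1 to compound 3 (1.00 log units; beyond the scatter) and is thus a second halogen, at a different ring place, that goes with a number beyond the scatter of compound 1. No measurement on hand bears on the reason for this.

Compound 2 and compound 3 differ in both the halogen and its place on the phenyl ring, so the share of each in the result cannot be read. From the compounds shown here alone, whether a halogen is needed at all also stays open, and a methoxy group, a nitrile or an amine on this phenyl ring would address that.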